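The source may hold more compounds than are shown below. What is called first, only, known or untested is meant among the compounds shown, and "the series" means these compounds.

Of the compounds shown here, three sharing one core have been measured in a functional assay on A-375 cells (Homo sapiens) for antiproliferative activity, read by CCK-8 assay, with a stated time of 72 h, tested at 2 uM; on this read-out higher numbers stand for a stronger effect at the one concentration tested and lower numbers for a weaker effect. Compound 1 `Nc1ccccc1NC(=O)c1ccc(CSC(=S)N2CCN(C(c3ccccc3)c3ccccc3)CC2)cc1` gives 8.7% in this assay. Compound 2 `Nc1ccccc1NC(=O)c1ccc(CSC(=S)N2CCN(c3ccc(F)cc3)CC2)cc1` gives 20.9% in this assay. Compound 3 `Nc1ccccc1NC(=O)c1ccc(CSC(=S)N2CCc3cc([N+](=O)[O-])ccc32)cc1` gives 16.9% in this assay.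

Among these three numbers, compound 2 stands highest. The nearest to it is compound 3, whose number lies within the scatter of repeated measurements, so the two cannot be told apart. The furthest is compound 1, whose number lies beyond the scatter, so compound 2 sits clearly above compound 1. Going by the values given here, no pair among the three differs in only one place, so none of them shows the effect of a single change.

Compound 4 `Nc1ccccc1NC(=O)c1ccc(CSC(=S)N2CCN(c3cnccn3)CC2)cc1` has not yet been measured. It differs from compound 2 in one place: pyrazin-2-yl in place of 4-fluorophenyl on an amine nitrogen in a ring. Among the compounds with values here, no measured pair shows what such an exchange does on this core, so the step can only be estimated. The expected step, a number 4.9 percentage points lower from compound 2 to compound 4 (within the scatter), is small and lies within the scatter, if anything downward. Compound 4 is therefore expected to give 16% in this assay, with a range from 2% to 30%.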

Compound 4, a percentage reported as inhibition, at one concentration (the size of the read-out at that concentration, not a potency): 29.1%
For compound 4 the middle estimate is 13.1 percentage points below the measured one, within the range that was stated.
By their numbers in this assay, from the lowest: compounds 1, 3, 2 and 4 (each within the scatter of the next, the first and the last beyond it).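

In this assay, going by these compounds alone, exchanging 4-fluorophenyl for pyrazin-2-yl on the amine nitrogen in the ring gives a number 8.2 percentage points higher from compound 2 to compound 4 (within the scatter) and is the first single change on the shared core that can be read, though the two compounds cannot be told apart. At this position, then, a carbon-only aromatic ring with 0 hydrogen-bond acceptors and an aromatic ring with 2 hetero atoms and 2 hydrogen-bond acceptors give numbers that lie within the usual scatter of each other, and this one pair is all that supports that reading. No measurement shown here speaks to what lies behind this step.

The compounds shown leave open how an unsubstituted phenyl, a pyridin-2-yl or a pyrimidin-2-yl would read at this nitrogen, and whether a small acetyl or methyl group there would stay within the scatter of compound 2 and compound 4 or fall clearly away from them. Since the read-out is taken at one concentration, they also leave open whether compound 2 and compound 4 would differ in potency.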